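A few compounds are considered here, and "the series" means these few. Any claim that something is new, unique, unknown or untested is made for them only; others in the source may bear on it.

Compound 1 `CC(=O)/N=C1\NCCC(c2cn(C)c3ccccc23)N1`: 10700 nM
Compound 2 `CC(=O)/N=C1\NCCC(c2cn(C)c3ccc(Br)cc23)N1`: 430 nM
Compound 3 `CC(=O)/N=C1\NCCC(c2cn(C)c3cc(Br)ccc23)N1`: not yet measured

For the measured compounds named here, in a functional assay on A549 cells (Homo sapiens) for cytotoxicity, read by sulforhodamine B assay, with a stated time of 72 h (a higher number here means a weaker inhibitor of growth, a lower number a stronger inhibitor of growth), compound 1 gives 10700 nM, the higher of the two numbers so far. Compound 3 changes compound 1 by one substitution: bromo in place of hydrogen on an aromatic carbon. Going by the values given here, the only measured step that bears on this is a 25-fold lower number from compound 1 to compound 2 (1.40 log units; beyond the scatter), a large step that also adds a bromo, but on a different aromatic carbon. A lower number is therefore expected, though the size of the drop may not carry over to the new place. The expected change is a 7.1-fold lower number from compound 1 to compound 3 (0.85 log units; beyond the scatter). Compound 3 is estimated at 1500 nM, with an expected range of 350 nM to 6500 nM.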

Compound 3, concentration for 50% growth inhibition: 6300 nM
Compound 3: the middle estimate sits 4.2-fold (0.62 log units) below what was measured; the measured number falls inside the stated range.
By their numbers in this assay, from the lowest: compound 2; then compounds 3 and 1 (each within the scatter of the next).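

In this assay, bromo on this aromatic carbon gives a 1.7-fold lower number from compound 1 to compound 3 (0.23 log units; within the scatter), so here the change cannot be told apart from the usual scatter. The large earlier step therefore does not come with bromo alone: it depends on which aromatic carbon carries it, as compound 2 at 430 nM and compound 3 at 6300 nM show. Nothing measured here explains this difference. Still open, on these data alone, is whether fluoro or methoxy on this same carbon would read like bromo. Also open, as far as these compounds go, is whether chloro on the carbon bearing bromo in compound 2 would keep that low number.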